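Amine substituent variation on the 5-hydroxytryptamine receptor 1B series

The compounds below may be only part of what the source reports. "The series", "measured", "known", "first", "only" and "open" are said of these compounds alone.

Measured compounds:
compound 1 `c1cncc(CNC2CCN(CCCc3c[nH]c4ccc(-n5cnnc5)cc34)CC2)c1`: 140 nM
compound 2 `CN(C1CCN(CCCc2c[nH]c3ccc(-n4cnnc4)cc23)CC1)S(=O)(=O)c1ccccc1`: 10 nM
compound 3 `CC(=O)Nc1ccc(CNCC2CCN(CCCc3c[nH]c4ccc(-n5cnnc5)cc34)CC2)cc1`: 8.9 nM

In an assay on CHO cells for displacement of a labelled ligand from 5-hydroxytryptamine receptor 1B (Homo sapiens) (a lower number here means a stronger inhibitor, a higher number a weaker inhibitor), compound 3 gives the lowest of the three numbers, but its value lies within the scatter of compound 2; only compound 1 is clearly apart from it. Within the data shown here, the one step measured in one place, a 14-fold lower number from compound 1 to compound 2 (1.15 log units; beyond the scatter), concerns a different position and does not directly inform the present change. Compound 4 `c1ccc2c(c1)CCC2NCC1CCN(CCCc2c[nH]c3ccc(-n4cnnc4)cc23)CC1` differs from compound 3 in one place: 2,3-dihydro-1H-inden-1-yl in place of 4-acetamidobenzyl on an amine nitrogen. No measured pair shares this change, so the expectation rests on the observation that the three shown substituents on the amine nitrogen all fall within a modest span. A step of a 1.7-fold higher number from compound 3 to compound 4 (0.23 log units; within the scatter) is expected, probably a small loss. Compound 4 is estimated at 15 nM, with a range of 4 nM to 60 nM.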

Compound 4, half-maximal inhibitory concentration: 25 nM
For compound 4 the middle estimate is 1.7-fold (0.22 log units) below the measured one, and the stated range covers the measured number.
By their numbers in this assay, from the lowest: compounds 3 and 2 (each within the scatter of the next); then compound 4; then compound 1.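

On the amine nitrogen, 2,3-dihydro-1H-inden-1-yl in place of 4-acetamidobenzyl gives a 2.8-fold higher number from compound 3 to compound 4 (0.45 log units; beyond the scatter) in this assay, so this substituent shifts the number beyond the scatter, though only modestly. Compound 4 also stands clear of the two compounds changed on the saturated ring carbon, with a 2.5-fold higher number from compound 2 to compound 4 (0.40 log units; beyond the scatter) and with a 5.6-fold lower number from compound 1 to compound 4 (0.75 log units; beyond the scatter). Nothing measured here accounts for these steps.

A plain benzyl on the same amine nitrogen would separate the departure of the acetamido group from the entry of the five-membered ring. From the compounds shown here alone, how much of the step belongs to each remains open.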